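A few compounds are considered here, and "the series" means these few. Any claim that something is new, unique, unknown or untested is made for them only; others in the source may bear on it.

Measured so far in a functional assay on A549 cells (Homo sapiens) for antiproliferative activity, read by MTT assay, with a stated time of 48 h; on this read-out lower numbers stand for stronger inhibition and higher numbers for weaker inhibition:

Compound 1 `N#CC1=C(N)Oc2c(c3nc4ccccc4nc3c3ccccc23)C12C(=O)N(Cc1cnnn1-c1ccc(Cl)cc1)c1ccccc12` sits at a limit of this assay, > 50000 nM.
Compound 2 `N#CC1=C(N)Oc2c(c3nc4ccccc4nc3c3ccccc23)C12C(=O)N(Cc1cnnn1-c1ccc(N)cc1)c1ccccc12` sits at a limit of this assay, > 50000 nM.
Compound 3 `N#CC1=C(N)Oc2c(c3nc4ccccc4nc3c3ccccc23)C12C(=O)N(Cc1cnnn1-c1cccc(S(N)(=O)=O)c1)c1ccccc12` gives 44200 nM.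

Among the measured compounds shown here, compound 3 thus holds the only number in this assay; the other two values are limits, as noted in the limit of > 50000 nM in this assay, at which 2 of the 3 values shown sit.

Compound 4 `N#CC1=C(N)Oc2c(c3nc4ccccc4nc3c3ccccc23)C12C(=O)N(Cc1cnnn1-c1ccc(Cl)c(Cl)c1)c1ccccc12` differs from compound 3 by 3,4-dichlorophenyl in place of 3-sulfamoylphenyl on an aromatic nitrogen. The measured steps that bear on this run the other way, from a halogen- or amino-bearing phenyl to the sulfamoylphenyl: an at least 1.1-fold lower number from compound 1 to compound 3 (0.05 log units; that floor lies within the scatter) and an at least 1.1-fold lower number from compound 2 to compound 3 (0.05 log units; that floor lies within the scatter), both within the scatter. Reverting to a chloro-bearing phenyl is therefore expected to give no step beyond the scatter, a 1.1-fold higher number from compound 3 to compound 4 (0.05 log units; within the scatter), with a real chance that only a limit is reported. Compound 4 is expected near 50000 nM, between 20000 nM and 150000 nM.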

Compound 4, half-maximal inhibitory concentration: > 50000 nM
Compound 4 gave a limit, no number; the forecaster's own chance of this, stated with the estimate: 55%; the middle value lies on the limit itself.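

In this assay, 3,4-dichlorophenyl in place of 3-sulfamoylphenyl gives an at least 1.1-fold higher number from compound 3 to compound 4 (0.05 log units; that floor lies within the scatter), so this change on the aromatic nitrogen shows no step beyond the scatter. A second chloro on the phenyl also yields no number, and the steps from compound 1 and from compound 2 to compound 4 cannot be read, since both ends of each are limits. Compound 3 remains the only compound with a number: the limit of > 50000 nM in this assay, at which 3 of the 4 values shown sit.

Open, on these data alone, is whether 4-sulfamoylphenyl or a phenyl bearing a carboxylic acid would give a number here. Also open, as far as these compounds go, is how a saturated alkyl chain in place of the phenyl would read out.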